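The compounds below may be only part of what the source reports. "The series", "measured", "known", "first", "only" and "open" are said of these compounds alone.

Working notes on the shared core. Compound 1 is `CCNC(=O)CCc1cccc2c1B(O)OC2`, compound 2 is `O=C(CCc1cccc2c1B(O)OC2)Nc1ccc(Br)cc1`, compound 3 is `O=C(CCc1cccc2c1B(O)OC2)Nc1ccc(I)cc1`. In a functional assay on MDA-MB-231 cells (Homo sapiens) for antiproliferative activity, read by MTT assay, with a stated time of 72 h (a lower number here means a stronger inhibitor, a higher number a weaker inhibitor), compound 1 gives only a limit, > 100000 nM (the limit of > 100000 nM in this assay, at which 1 of the 3 values shown sits). Compound 2 gives 5300 nM. Compound 3 gives 33000 nM. The steps of an at least 18-fold lower number from compound 1 to compound 2 (1.27 log units; beyond the scatter) and an at least 3.0-fold lower number from compound 1 to compound 3 (0.48 log units; beyond the scatter) both start from a limit; between the two aryl amides, a 6.2-fold higher number from compound 2 to compound 3 (0.79 log units; beyond the scatter). Compound 2 thus holds the lowest of the two numbers, with compound 3 nearest. Compound 4 is `O=C(CCc1cccc2c1B(O)OC2)Nc1ccc([N+](=O)[O-])cc1`; it differs from compound 2 by nitro in place of bromo on an aromatic carbon. Among the compounds with values here, only the step from compound 2 to compound 3 changes the same aromatic carbon, and it was modest; no measured step involves nitro. A modest rise from compound 2 is expected, a 2.3-fold higher number from compound 2 to compound 4 (0.35 log units; beyond the scatter). Compound 4 is estimated at 12000 nM, within 3500 nM to 45000 nM.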

Compound 4, half-maximal inhibitory concentration: 36000 nM
Estimate against measurement, compound 4: 3.0-fold (0.48 log units) below; the measured number falls inside the stated range.
By their numbers in this assay, from the lowest: compound 2; then compounds 3 and 4 (each within the scatter of the next). At a limit, above all of these: compound 1.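

At this aromatic carbon, para to a large group, the second replacement of bromo also moves the number beyond the scatter in this assay: a 6.8-fold higher number from compound 2 to compound 4 (0.83 log units; beyond the scatter). Nitro in place of iodo gives a 1.1-fold higher number from compound 3 to compound 4 (0.04 log units; within the scatter), so these two replacements cannot be told apart here, although the entering groups differ. No available measurement bears on why bromo stands apart from both.

Open, on these data alone, is whether an amine, a carboxylic acid or chloro on this carbon would stay near compound 2. Also open, as far as these compounds go, is what a longer chain on the shared core would do.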